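Swapping benzyl for cyclobutylmethyl on a sulfonamide nitrogen

This account rests on a few compounds, and the source may have more. Where it says the series, first, only, none or still open, it means among the compounds named here.

Compound 1 (`CCc1ccc(N(Cc2ccccc2)S(=O)(=O)c2ccc3c(c2)C(=O)CC(C2CCOCC2)O3)cc1`) gives 4.84
Compound 2 (`CCc1ccc(N(CC(C)C)S(=O)(=O)c2ccc3cc(OCC4CCOCC4)c(CO)cc3c2)cc1`) gives 5.1
Compound 3 (`Cc1ccc(NS(=O)(=O)c2ccc3c(c2)C(=O)CC(C2CCOCC2)O3)c(C)c1`) gives 2.75

In a physicochemical assay for lipophilicity, at pH 7.4 (a higher number here means a more lipophilic compound, a lower number a more polar compound), compound 1 stands second highest of the three numbers. Its value and that of compound 2 lie within the scatter of each other, so no order between them can be read; compound 3 lies well lower, beyond the scatter. Compound 4 (`CCc1ccc(N(CC2CCC2)S(=O)(=O)c2ccc3c(c2)C(=O)CC(C2CCOCC2)O3)cc1`) has not yet been measured. It differs from compound 1 in one place: cyclobutyl in place of phenyl on a saturated chain carbon bound to a sulfonamide nitrogen. Within the data shown here, no step between measured compounds shows what this swap does in this assay, so the size of the change is open. A small decrease, or none beyond the scatter, is expected, with the estimated step of a number 0.29 log units lower from compound 1 to compound 4 (within the scatter). Compound 4 is therefore estimated at 4.55, within a range from 4.1 to 5.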

Compound 4, distribution coefficient: 4.1
Beside the measured number, compound 4's estimate is 0.45 log units above it; measured number inside the range.
By their numbers in this assay, from the lowest: compound 3; then compound 4; then compounds 1 and 2 (each within the scatter of the next).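

Among these compounds, with the core of compound 1 held constant, this is the first reading at this position in this assay. Replacing phenyl with cyclobutyl on a saturated chain carbon bound to a sulfonamide nitrogen moves the number beyond the scatter (a number 0.74 log units lower from compound 1 to compound 4 (beyond the scatter)), so this place is not silent to the change. Nothing measured here accounts for the step. The compounds shown leave open whether the loss of the aromatic ring or the smaller ring goes with this step, and cyclohexyl at this place would separate the two. From the compounds shown here alone, how an amine or a longer chain would read there also remains open.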